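The source may report more compounds than this note shows. Statements on the series, on what has been measured and on what is new or still open speak of the compounds shown alone.

In a functional assay on BGC-823 cells (Homo sapiens) for inhibition, read by CCK-8 assay, with a stated time of 48 h (a lower number here means a stronger inhibitor, a higher number a weaker inhibitor), compound 1 `COc1ccc(C2=NN(C3=NC(c4ccccc4)CS3)C(c3cccc4ccccc34)C2)cc1` gives 9510 nM, compound 2 `O=C1CSC(N2N=C(c3ccc(Cl)cc3)CC2c2cccc3ccccc23)=N1` gives 16400 nM and compound 3 `Clc1ccc(C2=NN(C3=NC(c4ccccc4)CS3)C(c3cccc4ccccc34)C2)cc1` gives 19600 nM. Compound 2 lies within the usual scatter of both other compounds, even though these two are separated by a step just beyond it. Compound 4 `Cc1ccc(C2=NN(C3=NC(=O)CS3)C(c3cccc4ccccc34)C2)cc1` keeps the core of compound 2 and carries methyl in place of chloro on an aromatic carbon, para to a large group: methyl in place of chloro on an aromatic carbon. Going by the values given here, no measured step involves methyl. The closest evidence is a 2.1-fold higher number from compound 1 to compound 3 (0.31 log units; beyond the scatter), a modest step in which chloro replaces methoxy on an aromatic carbon. A second step, a 1.2-fold higher number from compound 2 to compound 3 (0.08 log units; within the scatter), changes a different place and stays within the scatter, which suggests that the chloro compounds of the two cores read alike. A small shift towards a lower number is therefore expected, but nothing beyond the scatter, and the estimate amounts to a 1.3-fold lower number from compound 2 to compound 4 (0.10 log units; within the scatter). Compound 4 is expected at about 13000 nM, with an estimated range of 6500 nM to 26000 nM.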

Compound 4, half-maximal inhibitory concentration: 10000 nM
The estimate for compound 4 lay 1.3-fold (0.11 log units) above the measured number, and the stated range covers the measured number.
By their numbers in this assay, from the lowest: compounds 1, 4, 2 and 3 (each within the scatter of the next, the first and the last beyond it).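

In this assay, replacing 4-chlorophenyl with 4-methylphenyl on the core of compound 2 gives a 1.6-fold lower number from compound 2 to compound 4 (0.21 log units; within the scatter), so this assay does not separate methyl from chloro at this place, para to a large group. The earlier compounds had shown this place only on the other core and only with methoxy and chloro, in a 2.1-fold higher number from compound 1 to compound 3 (0.31 log units; beyond the scatter), a step just beyond the scatter, whereas this first step involving methyl stays within it. No measurement shown here explains this result.

Going by these compounds, it remains open whether an amine or a carboxylic acid at this place would shift the number beyond the scatter. On these data alone, it is also open whether methyl on the core of compound 1 would read like chloro, as it does on the core of compound 2.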